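Changing the Aryl Group on the Amine of a Urea Series

A few compounds are considered here, and "the series" means these few. Any claim that something is new, unique, unknown or untested is made for them only; others in the source may bear on it.

Measured compounds in a functional assay on NCI-H520 cells (Homo sapiens) for inhibition, read by MTT assay, with a stated time of 48 h, tested at 10 uM; on this read-out lower numbers stand for less inhibition and higher numbers for more inhibition at the one concentration tested (going by the name of the read-out):
- compound 1, `CCc1ccc(Nc2cc(NC(=O)Nc3c(Cl)cccc3Cl)ncn2)cc1`, gives 31.5%
- compound 2, `COc1ccc(OC)c(Nc2cc(NC(=O)Nc3c(Cl)cccc3Cl)ncn2)c1`, gives 74%
- compound 3, `COc1ccc(F)cc1Nc1cc(NC(=O)Nc2c(Cl)cccc2Cl)ncn1`, gives 38.1%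

Compound 3 stands second highest of the three numbers. Its number and that of compound 1 lie within the scatter of each other, so they cannot be told apart, while compound 2 sits well above it, as the step of a number 35.9 percentage points lower from compound 2 to compound 3 (beyond the scatter) shows, which came with fluoro in place of methoxy on an aromatic carbon.

Compound 4, `COc1ccc(Nc2cc(NC(=O)Nc3c(Cl)cccc3Cl)ncn2)cc1C`, is not yet measured. It differs from compound 3 by 4-methoxy-3-methylphenyl in place of 5-fluoro-2-methoxyphenyl on a nitrogen on an aromatic ring.

Within the data shown here, two measured steps bear on this. The step of a number 6.6 percentage points higher from compound 1 to compound 3 (within the scatter) shows that exchanging the whole aryl group on this nitrogen can leave the number unchanged. The step of a number 35.9 percentage points lower from compound 2 to compound 3 (beyond the scatter) shows that a methoxy group on that aryl ring can matter greatly. Compound 4 keeps one methoxy group, so a rise is expected, but smaller than the step from compound 2 to compound 3.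

Compound 4 is expected to give 52%, between 28% and 76%, an estimated step of a number 13.9 percentage points higher from compound 3 to compound 4 (beyond the scatter).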

Compound 4, a percentage reported as inhibition, at one concentration (the size of the read-out at that concentration, not a potency): 29.1%
Estimate against measurement, compound 4: 22.9 percentage points above; low and high end bracket the measured number.
By their numbers in this assay, from the lowest: compounds 4, 1 and 3 (each within the scatter of the next); then compound 2.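

Swapping 5-fluoro-2-methoxyphenyl for 4-methoxy-3-methylphenyl on this nitrogen gives a number 9 percentage points lower from compound 3 to compound 4 (within the scatter), and swapping 4-ethylphenyl for it gives a number 2.4 percentage points lower from compound 1 to compound 4 (within the scatter), so in this assay these three aryl groups cannot be told apart. A single methoxy group on the ring is therefore not enough for a high number here: compound 3 and compound 4 each carry one, yet both remain within the scatter of compound 1, which has none, and only compound 2, with two methoxy groups, reaches 74%. No measurement available here explains why compound 2 stands apart.

The compounds shown leave open whether the high number of compound 2 needs both of its methoxy groups, as no compound here tests each one alone. They also leave open how this aryl ring would respond to an amine, a carboxylic acid or a longer ether chain.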